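Swapping the Side Group on Compound 2

The source may hold more compounds than are shown below. What is called first, only, known or untested is meant among the compounds shown, and "the series" means these compounds.

In an ADME assay on HepG2 2.2.15 cells (Homo sapiens) for cytotoxicity (on this read-out higher numbers stand for lower toxicity in this test and lower numbers for higher toxicity in this test), compound 1 `CC12CCC(C(=O)OCCc3c(-c4ccccc4Cl)c4cc(Cl)ccc4[nH]c3=O)(OC1=O)C2(C)C` gives > 1800000 nM, which is a limit of the test and not an exact number. Going by the values given here, compound 2 `O=C(COc1ccccc1)OCCc1c(-c2ccccc2Cl)c2cc(Cl)ccc2[nH]c1=O` gives 81000 nM, the only exact value so far, and so the single firm reference point. Among the compounds with values here, the one measured step, an at least 22-fold lower number from compound 1 to compound 2 (1.34 log units; beyond the scatter), is large and lies beyond the usual scatter. It shows that the group on this carbonyl carbon can matter, but that swap exchanged two very different groups.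

Compound 3 `O=C(/C=C/c1ccccc1)OCCc1c(-c2ccccc2Cl)c2cc(Cl)ccc2[nH]c1=O` keeps the shared core and makes a much smaller change: 2-phenylethenyl in place of phenoxymethyl on a carbonyl carbon. The six-membered aromatic ring stays, and a double bond enters the chain. Within the data shown here, with only one large step to go on, and that one from a far bigger replacement, a jump of similar size is not expected here. The expected change, a 1.2-fold lower number from compound 2 to compound 3 (0.06 log units; within the scatter), is small and within the scatter, so the estimate stays close to compound 2 at 81000 nM. Compound 3 is expected to give about 70000 nM, with an estimated range of 25000 nM to 200000 nM.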

Compound 3, half-maximal cytotoxic concentration: 230000 nM
Estimate against measurement, compound 3: 3.3-fold (0.52 log units) below; the whole stated range lies below it.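

Even a swap that keeps the six-membered aromatic ring moves the result in this assay, with a 2.8-fold higher number from compound 2 to compound 3 (0.45 log units; beyond the scatter). The earlier step exchanged two very different groups, whereas this one changes only phenoxymethyl, with its oxygen and its hydrogen-bond acceptor, to 2-phenylethenyl, with its double bond and no hydrogen-bond acceptor, on a carbonyl carbon, so this position responds to a much smaller change than the first step could show. Compound 3 still lies well under compound 1, with an at least 7.8-fold lower number from compound 1 to compound 3 (0.89 log units; beyond the scatter), a step that has only one exact end and rests on a limit of the test: the limit of > 1800000 nM in this assay, at which 1 of the 3 values shown sits.

The oxygen and the double bond change together in this one swap, and the compounds shown do not separate the two. On these data alone, how a saturated 2-phenylethyl group, or a group carrying an amine or a carboxylic acid, would read on this carbonyl carbon remains open.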